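The source may hold more compounds than are shown below. What is called first, only, known or untested is meant among the compounds shown, and "the series" means these compounds.

Within the data shown here, in an ADME assay on Huh-7 cells (Homo sapiens) for cytotoxicity, read by MTT assay, with a stated time of 4 h, at 37 degrees C (a lower number here means that less compound is tolerated, a higher number that more compound is tolerated), compound 2 `Cn1c(=O)c(-c2ccccc2)cc2c(N)nc(Nc3ccccc3)nc21` gives 23500 nM, the higher of the two numbers so far, and compound 1 `Cn1c(=O)c(-c2c(F)cccc2C(F)(F)F)cc2c(N)nc(Nc3ccccc3)nc21` gives 6300 nM. The gap between these two compounds lies beyond the usual scatter. Compound 3 `Cn1c(=O)c(-c2c(F)cccc2F)cc2c(N)nc(Nc3ccccc3)nc21` is still unmeasured. It carries 2,6-difluorophenyl in place of phenyl on an aromatic carbon. Among the measured compounds shown here, no measured pair shows this change alone, and the lower value of compound 1 at 6300 nM is the only guide. A modest fall in this assay is therefore expected, an estimated 1.8-fold lower number from compound 2 to compound 3 (0.26 log units; within the scatter). Compound 3 is estimated at 13000 nM, with an expected range of 6000 nM to 28000 nM.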

Compound 3, half-maximal cytotoxic concentration: 10400 nM
Estimate against measurement, compound 3: 1.3-fold (0.10 log units) above, and the stated range covers the measured number.
By their numbers in this assay, from the lowest: compounds 1 and 3 (each within the scatter of the next); then compound 2.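

In this assay, among these compounds, the swap of phenyl for 2,6-difluorophenyl on this aromatic carbon, taken alone, moves the number beyond the scatter (a 2.3-fold lower number from compound 2 to compound 3 (0.35 log units; beyond the scatter)), which no earlier pair could show. Fluoro in place of trifluoromethyl on that ring gives a step within the scatter (a 1.7-fold higher number from compound 1 to compound 3 (0.22 log units; within the scatter)), so compound 1 and compound 3 cannot be told apart here. Nothing measured here gives a reason for either step. Still open, going by these compounds, is how this assay would read with an amine or a methoxy group on that ring instead of fluoro or trifluoromethyl.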